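Adding an amine to the acetyl group of compound 2

A few compounds are considered here, and "the series" means these few. Any claim that something is new, unique, unknown or untested is made for them only; others in the source may bear on it.

Compound 1 `CC(=O)NCC(=O)N1CCc2c(C)c3c(n2-c2ccc(C(N)=O)c(c2)N[C@@H](C)CC1)CC(C)(C)CC3=O`: > 0.5 h
Compound 2 `CC(=O)N1CCc2c(C)c3c(n2-c2ccc(C(N)=O)c(c2)N[C@@H](C)CC1)CC(C)(C)CC3=O`: 0.15 h

Among the compounds with values here, in an in vitro ADME assay on microsomes from liver (Rattus norvegicus) for metabolic stability (a higher number here means that the compound lasts longer, a lower number that the compound disappears faster), compound 2 gives 0.15 h, the only exact number so far. Compound 1 gives > 0.5 h, which is a limit of the assay and not a number.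

Compound 3 `Cc1c2c(n3c1CCN(C(=O)[C@@H](C)N)CC[C@H](C)Nc1cc-3ccc1C(N)=O)CC(C)(C)CC2=O` keeps the core of compound 2 but changes acetyl to (1-aminoethyl)carbonyl: 1-aminoethyl in place of methyl on a carbonyl carbon. Within the data shown here, one measured step bears on this: an at least 3.3-fold lower number from compound 1 to compound 2 (0.52 log units; beyond the scatter). Read in reverse, that step suggests a longer half-life when a nitrogen-bearing group sits on the chain. A free amine is not an acetamido group, however, so only part of that size is expected, as a modest rise. The expected change in this assay is a 2.3-fold higher number from compound 2 to compound 3 (0.37 log units; beyond the scatter). For compound 3 the estimated half-life is 0.35 h, with an expected range of 0.13 h to 0.9 h.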

Compound 3, half-life in the Rattus norvegicus assay: > 0.5 h
Compound 3: only a limit was reported; the forecaster's own chance of this, stated with the estimate: 30%; middle value at least 1.4-fold (0.15 log units) away from the limit.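

With 1-aminoethyl in place of methyl on a carbonyl carbon, the Rattus norvegicus assay shows an at least 3.3-fold higher number from compound 2 to compound 3 (0.52 log units; beyond the scatter) and so a free amine on this chain goes with a rise of the kind first seen with the acetamido group of compound 1. The step between compound 1 and compound 3 cannot be read, because both values are limits of the assay and not numbers: the limit of > 0.5 h in the Rattus norvegicus assay, at which 2 of the 3 values shown sit. The same change also brings, in a physicochemical assay for solubility (a lower number here means a less soluble compound, a higher number a more soluble compound), an at least 5.2-fold higher number from compound 2 to compound 3 (0.72 log units; beyond the scatter). In the physicochemical assay compound 2 gives 19 ug/mL. In the physicochemical assay compound 3 gives > 100 ug/mL, which is a limit of the assay and not a number. The size of this step is only a floor, because the value of compound 3 is again a limit: the limit of > 100 ug/mL in the physicochemical assay, at which 1 of the 2 values shown sits.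

Going by these compounds, how far compound 3 lies past either limit stays open, so the full size of both steps is unknown. The compounds shown also leave open whether a hydroxyl group, a carboxylic acid or a longer chain ending in an amine would do the same, and whether the opposite stereocentre in 1-aminoethyl would match it.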